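A few compounds are considered here, and "the series" means these few. Any claim that something is new, unique, unknown or untested is made for them only; others in the source may bear on it.

In a functional assay for inhibition, with Rattus norvegicus as the target (a higher number here means a weaker inhibitor, a lower number a stronger inhibitor), compound 1 `Nc1c(Nc2cccnc2)c(=O)c1=O` gives > 30000 nM as a limit of the assay and not as a number. Compound 2 `COC(=O)c1ccc(Nc2c(NC(C)C(C)(C)C)c(=O)c2=O)cc1` likewise gives > 30000 nM as a limit of the assay. Compound 3 `CC(C)C(C)/N=c1\c(O)c(O)\c1=N/c1ccc(C#N)cc1` is the only one of the three with an actual number, reading 1900 nM in this assay.

Compound 4 `CC(C)/N=c1\c(O)c(O)\c1=N/c1ccc(C#N)cc1` has not yet been measured. It differs from compound 3 in one place, with methyl in place of isopropyl on a saturated chain carbon bound to a double-bonded nitrogen and a saturated chain carbon.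

Going by the values given here, no measured pair shows this change, so the forecast is tentative. A moderate weakening is expected in this assay with the number going up (estimated step a 2.6-fold higher number from compound 3 to compound 4 (0.42 log units; beyond the scatter)). The reading of compound 3 (1900 nM) leaves room for such a rise within the measurable range. For compound 4 the estimated value is 5000 nM (expected range 1800 nM to 20000 nM).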

Compound 4, half-maximal inhibitory concentration: 13700 nM
The estimate for compound 4 lay 2.7-fold (0.44 log units) below the measured number; low and high end bracket the measured number.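

In this assay, going by these compounds alone, cutting 1,2-dimethylpropyl back to isopropyl gives a 7.2-fold higher number from compound 3 to compound 4 (0.86 log units; beyond the scatter), the first single change in these compounds whose size can be read. It shows that the number responds to this position, on a saturated chain carbon bound to a double-bonded nitrogen and a saturated chain carbon, although the change removes only carbon and no hydrogen-bond donor or acceptor. Compound 4 still gives a measured number, though the scale above it is short: the limit of > 30000 nM in this assay, at which 2 of the 4 values shown sit.

The compounds shown leave open whether a longer chain, a cyclohexyl ring or an amine in this place would lower the number further than the 1,2-dimethylpropyl group does. They also leave open whether this change would have a step of similar size with a group other than the nitrile-bearing one on the far side of the core.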